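The compounds below may be only part of what the source reports. "The series", "measured", "known", "first", "only" and "open" are said of these compounds alone.

Working notes on the series. The shared core is common to compound 1 `Nc1nc(NCc2ccccc2)nc(-c2ccccc2CO)n1`, compound 2 `Nc1nc(NCc2ccccc2)nc(-c2cc(Cl)ccc2CO)n1` and compound 3 `COc1ccc(CO)c(-c2nc(N)nc(NCc3ccccc3)n2)c1`. In a functional assay on cells for positive allosteric modulation of G-protein coupled receptor 68 (Homo sapiens), read by a luciferase reporter and cAMP accumulation, with a stated time of 30 min, at pH 6.8 and pH 8.3, in the presence of a further agent that is not named here (on this read-out lower numbers stand for lower potency and higher numbers for higher potency (the scale is a negative logarithm)), compound 1 gives 4.35; in the same assay compound 2 gives 4.49 and compound 3 gives 3.99. Compound 2 holds the highest number of the three, though a number 0.14 log units higher from compound 1 to compound 2 (within the scatter), so compound 1 and compound 2 cannot be told apart on these numbers; a number 0.50 log units lower from compound 2 to compound 3 (beyond the scatter) and a number 0.36 log units lower from compound 1 to compound 3 (beyond the scatter) do set compound 3 apart from both.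

Compound 4 `Nc1nc(NCCCCc2ccccc2)nc(-c2cc(Cl)ccc2CO)n1` is not yet measured. The change from compound 2 to compound 4 is 3-phenylpropyl in place of phenyl on a saturated chain carbon bound to a nitrogen on an aromatic ring. Among the compounds with values here, every measured step so far concerns a chloro or methoxy in place of hydrogen on an aromatic carbon; none alters the saturated chain carbon bound to a nitrogen on an aromatic ring. Within the data shown here, the steps from compound 1 to compound 2 and from compound 2 to compound 3 therefore do not bear on this change, and the series gives no precedent for lengthening the chain. With nothing to point either way, the expectation in this assay for compound 4 is no step beyond the scatter, with a wide range left for an effect the series has not shown. The step expected from compound 2 to compound 4 is a number 0.09 log units lower from compound 2 to compound 4 (within the scatter). Compound 4 is estimated at 4.4, between 3.8 and 5.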

Compound 4, negative logarithm of the antagonist equilibrium constant: 4.98
Compound 4: middle estimate off by 0.58 log units, on the low side; low and high end bracket the measured number.
By their numbers in this assay, from the lowest: compound 3; then compounds 1 and 2 (each within the scatter of the next); then compound 4.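

In this assay, the saturated chain carbon bound to a nitrogen on an aromatic ring proves to be a place that responds to change: a number 0.49 log units higher from compound 2 to compound 4 (beyond the scatter), with 3-phenylpropyl in place of phenyl. The earlier steps all lay on an aromatic carbon, where chloro could not be told apart from hydrogen and methoxy lowered the number, so this is the first step shown that raises the number beyond the scatter, though only modestly. Nothing measured on hand explains this gain.

Going by these compounds, with only phenyl and 3-phenylpropyl compared at this place, it remains open whether the number tracks chain length, which 2-phenylethyl and 4-phenylbutyl would test, and whether the phenyl ring on the chain is needed at all, which a plain butyl chain would test. On these data alone, it is also open whether 3-phenylpropyl gives a similar step on the cores of compound 1 and compound 3, which carry hydrogen and methoxy in place of the chloro.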